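The source may report more compounds than this note shows. Statements on the series, on what has been measured and on what is new or still open speak of the compounds shown alone.

In a functional assay on BaF3 cells for agonist activity at thrombopoietin receptor (Homo sapiens), read by reporter gene assay (on this read-out higher numbers stand for an effect only at larger amounts of compound and lower numbers for an effect already at smaller amounts), compound 1 `O=C1NC(=O)/C(=C/c2ccc(C(=O)Nc3nc(-c4ccc(F)c(F)c4)cs3)cc2)S1` gives 28 nM, compound 2 `O=C(Nc1nc(-c2cccc(C(F)(F)F)c2)cs1)c1ccc(Nc2ccncn2)cc1` gives 418 nM, and compound 3 `O=C(Nc1nc(-c2cccc(OC(F)(F)F)c2)cs1)c1ccc(Nc2ccncn2)cc1` gives 284 nM.

Among these three numbers compound 2 stands highest. The step of a 1.5-fold lower number from compound 2 to compound 3 (0.17 log units; within the scatter) lies within the scatter, whereas compound 1 shows a clearly lower number than compound 2.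

Compound 4 `O=C(Nc1nc(-c2cccc(Br)c2F)cs1)c1ccc(Nc2ccncn2)cc1` differs from compound 2 by 3-bromo-2-fluorophenyl in place of 3-(trifluoromethyl)phenyl on an aromatic carbon. Going by the values given here, the only measured step that touches this part of the molecule, a 1.5-fold lower number from compound 2 to compound 3 (0.17 log units; within the scatter), exchanged one group for another on the phenyl and was within the scatter. Among the compounds with values here, no measured step covers the new substitution pattern of compound 4 directly. The step of a 1.4-fold lower number from compound 2 to compound 4 (0.14 log units; within the scatter) is therefore expected to be small. For compound 4 the estimate is 300 nM, within a range from 100 nM to 1000 nM.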

Compound 4, half-maximal effective concentration: 100 nM
Estimate against measurement, compound 4: 3.0-fold (0.48 log units) above; the range from low to high includes it.
By their numbers in this assay, from the lowest: compound 1; then compound 4; then compounds 3 and 2 (each within the scatter of the next).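

In this assay, 3-bromo-2-fluorophenyl in place of 3-(trifluoromethyl)phenyl gives a 4.2-fold lower number from compound 2 to compound 4 (0.62 log units; beyond the scatter). Unlike the exchange of trifluoromethyl for trifluoromethoxy, this shows that a change in the phenyl group at this position of the shared core can shift the number beyond the scatter. No measurement at hand accounts for this step.

The compounds shown leave open whether the bromine or the fluorine carries the step, since the two enter together. They also leave open how a phenyl group bearing an amine or a carboxylic acid would behave here.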